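Capping a hydroxy group on an inactive compound

The compounds below may be only part of what the source reports. "The series", "measured", "known", "first", "only" and "open" are said of these compounds alone.

compound 1 `CCN(CC)C/C1=C/C[C@](C)(CCC=C(C)C)/C=C/[C@@H](OC(=O)C=C(C)C)[C@](C)(O)/C=C/C1=O`: 140 nM
compound 2 `CC[Si](CC)(CC)C/C1=C/C[C@](C)(CCC=C(C)C)/C=C/[C@@H](OC(=O)C=C(C)C)[C@](C)(O)/C=C/C1=O`: 2810 nM
compound 3 `CC(C)=CCC[C@]1(C)/C=C/[C@@H](OC(=O)C=C(C)C)[C@](C)(O)/C=C/[C@H](O)/C(CO)=C\C1`: > 40000 nM

All three values come from a functional assay on HL-60 cells (Homo sapiens) for antiproliferative activity, read by MTT assay, with a stated time of 48 h; a lower number here means a stronger inhibitor, a higher number a weaker inhibitor. For compound 3, the reading of > 40000 nM is a limit of the assay and not a number. It stands at the limit of > 40000 nM in this assay, at which 1 of the 3 values shown sits, so the data give no exact value for it.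

The next structure, compound 4 `CO[C@H]1/C=C/[C@@](C)(O)[C@H](OC(=O)C=C(C)C)/C=C/[C@@](C)(CCC=C(C)C)C/C=C\1CO`, has not yet been measured. It is compound 3 with one small change, methyl in place of hydrogen on an oxygen on a saturated carbon: hydroxy becomes methoxy.

Among the compounds with values here, only one measured step is available, a 20-fold higher number from compound 1 to compound 2 (1.30 log units; beyond the scatter). That step is large, so a single change on this shared core can matter a great deal in this assay. However, it replaces a different group elsewhere in the structure, so it gives neither a size nor a direction for the change from hydroxy to methoxy.

With no closer guide, the expectation is that compound 4 stays close to where compound 3 lies, with no clear shift in either direction. The expected change is small: a number no higher from compound 3 to compound 4 (the limit leaves the size open). Compound 4 is estimated at 40000 nM, with an expected range of 12000 nM to 100000 nM.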

Compound 4, half-maximal inhibitory concentration: 14900 nM
Compound 4: middle estimate off by 2.7-fold (0.43 log units), on the high side, within the range that was stated.
By their numbers in this assay, from the lowest: compound 1; then compound 2; then compound 4. At a limit, above all of these: compound 3.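

In this assay, capping the hydroxy group as methoxy gives an at least 2.6-fold lower number from compound 3 to compound 4 (0.42 log units; beyond the scatter), so this oxygen on a saturated carbon responds to a change as small as methyl in place of hydrogen. Within the data shown here, the earlier step between compound 1 and compound 2 concerned a different place on the shared core, so this is the first measured sign that this position matters. For compound 3, the reading of > 40000 nM is a limit of the assay and not a number, and the step therefore gives only a smallest possible size, because compound 3 has no exact value: the limit of > 40000 nM in this assay, at which 1 of the 4 values shown sits.

The compounds shown leave open whether a longer chain on this oxygen, such as ethyl, or an acetyl group in place of the methyl would lower the number further, and whether an amine in place of the methoxy would keep the change. On these data alone, it also stays open whether methyl on either of the other two hydroxy groups of compound 3 would act in the same way.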